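The compounds below may be only part of what the source reports. "The series", "measured", "known", "first", "only" and "open" are said of these compounds alone.

In an ADME assay on Huh-7 cells (Homo sapiens) for cytotoxicity, read by MTT assay, with a stated time of 72 h (a lower number here means that less compound is tolerated, a higher number that more compound is tolerated), compound 1 (`COc1cc(O)c(C(=O)/C=C/c2ccc(OC)c(OCc3cn(-c4ccccc4Cl)nn3)c2)c(OC)c1`) gives > 100 ug/mL, a limit of the assay and not a number. Compound 2 (`COc1cc(O)c(C(=O)/C=C/c2ccc(OCc3cn(-c4ccccc4Cl)nn3)c(OCc3cn(-c4ccccc4Cl)nn3)c2)c(OC)c1`) gives > 100 ug/mL, also a limit. Among the measured compounds shown here, the one measured step, a step that the two limits leave unreadable from compound 1 to compound 2, therefore offers no size to carry over, and the only guide left is the limit of > 100 ug/mL in this assay, at which 2 of the 2 values shown sit. Compound 3 (`COc1cc(O)c(C(=O)/C=C/c2ccc(OC)c(OCc3cn(-c4ccc(Cl)cc4)nn3)c2)c(OC)c1`) carries 4-chlorophenyl in place of 2-chlorophenyl on an aromatic nitrogen. No step beyond the scatter is expected in this assay, and no direction can be given. The expected change, a step that the limit leaves unreadable from compound 1 to compound 3, is an estimate only. For compound 3 the estimated value is 120 ug/mL, with an expected range of 50 ug/mL to 250 ug/mL.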

Compound 3, half-maximal cytotoxic concentration: > 100 ug/mL
Compound 3 gave a limit, no number; the forecaster's own chance of this, stated with the estimate: 80%; the middle value is on the limit's open side.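

Compound 1 and compound 3 both end at a limit of the assay in this assay, not a number, so no step between them can be read: the limit of > 100 ug/mL in this assay, at which 3 of the 3 values shown sit.

The compounds shown leave open whether 2-chlorophenyl and 4-chlorophenyl differ at all in this read-out, and at what concentration any of the three reaches half-maximal cytotoxicity.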